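The source may hold more compounds than are shown below. What is called first, only, known or untested is meant among the compounds shown, and "the series" means these compounds.

In a functional assay on SMMC-7721 cells (Homo sapiens) for cytotoxicity, read by MTT assay, with a stated time of 72 h (on this read-out lower numbers stand for stronger inhibition and higher numbers for weaker inhibition), compound 1 `CSC(=S)N[C@H]1CCOC1=O` gives > 128000 nM, which is a limit and not a number. Compound 2 `CCCCSC(=S)N[C@H]1CCOC1=O` gives > 128000 nM, also a limit, and the limit of > 128000 nM in this assay, at which 2 of the 2 values shown sit, is all the evidence so far. Compound 3 `CCCCCCCCSC(=S)N[C@H]1CCOC1=O` differs from compound 2 as follows: butyl in place of hydrogen on a saturated chain carbon, four bonds along the chain from a sulfur, with butyl in place of hydrogen on a saturated chain carbon. Among the measured compounds shown here, the only measured step, a step that the two limits leave unreadable from compound 1 to compound 2, offers no size to carry forward, so only a modest move toward stronger inhibition in this assay is expected. The expected change is an at least 1.2-fold lower number from compound 2 to compound 3 (0.10 log units; that floor lies within the scatter). For compound 3 the estimate is 100000 nM, with an expected range from 30000 nM to 200000 nM.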

Compound 3, half-maximal inhibitory concentration: 65100 nM
Estimate against measurement, compound 3: 1.5-fold (0.19 log units) above; the measured number falls inside the stated range.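

Butyl in place of hydrogen on a saturated chain carbon, four bonds along the chain from a sulfur, gives the first number rather than a limit in this assay, and with it the first step that has a size: an at least 1.9-fold lower number from compound 2 to compound 3 (0.29 log units; that floor lies within the scatter). That size is only a floor, and the step from compound 1 to compound 2 still cannot be read, because the series rests on a limit: the limit of > 128000 nM in this assay, at which 2 of the 3 values shown sit.

As far as these compounds go, whether a longer chain at this place lowers the number further stays open. So does what an amine or a carboxylic acid would do there.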